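A Charged Core Loses One Dec-1-en-1-yl Chain

The source may hold more compounds than are shown below. What is called first, only, known or untested is meant among the compounds shown, and "the series" means these compounds.

Measured compounds in a functional assay on DU-145 cells (Homo sapiens) for antiproliferative activity, read by WST assay, with a stated time of 72 h; on this read-out lower numbers stand for an effect already at smaller amounts and higher numbers for an effect only at larger amounts of compound:
compound 1, `CCCCCCCC/C=C\c1c(C)c(/C=C\CCCCCCCC)c2[n+](c1C)CCC2`, with 1 uM
compound 2, `CCCCCCCC/C=C/c1c(C)c(/C=C/CCCCCCCC)c2[n+](c1C)CCC2`, with 0.8 uM
compound 3, `CCCCCCCC/C=C\c1c(C)nc(C)c(/C=C\CCCCCCCC)c1C`, for which only a limit is recorded, > 30 uM

Compound 1 has the highest of the two numbers recorded in this assay, and its nearest neighbour is compound 2, which differs from it only in the configuration as drawn; the step of a 1.3-fold lower number from compound 1 to compound 2 (0.10 log units; within the scatter) lies within the scatter, as the fact that compounds 1 and 2 differ only in the configuration as drawn would lead one to accept. For the measured compounds named here, the value of compound 3 is a limit of the assay rather than a number, and the limit of > 30 uM in this assay, at which 1 of the 3 values shown sits, is the only other information about the set.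

Compound 4, `CCCCCCCC/C=C\c1c(C)cc(C)[n+]2c1CCC2`, is not yet measured. Relative to compound 1 it carries hydrogen in place of dec-1-en-1-yl on an aromatic carbon. Going by the values given here, no measured step touches a change of this kind: the only step in hand is the configurational one from compound 1 to compound 2, which is within the scatter, and the limit of compound 3 concerns a different core. The size and direction of the step in this assay can therefore not be read from the measurements shown.

Compound 4 is expected to give about 3 uM, within 0.8 uM to 12 uM, the estimate meaning a step of a 3.0-fold higher number from compound 1 to compound 4 (0.48 log units; beyond the scatter).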

Compound 4, concentration for half-maximal effect: 0.2 uM
Estimate against measurement, compound 4: 15-fold (1.18 log units) above, outside the stated range (below it).
By their numbers in this assay, from the lowest: compound 4; then compounds 2 and 1 (each within the scatter of the next). At a limit, above all of these: compound 3.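

Replacing dec-1-en-1-yl with hydrogen on this aromatic carbon, ortho to two methyl groups and two atoms from the ring nitrogen, gives in this assay a 5.0-fold lower number from compound 1 to compound 4 (0.70 log units; beyond the scatter), so on this core the chain at this position is not required for the effect. Compound 4 keeps the other dec-1-en-1-yl group, and with that single chain on the charged core it still reaches 0.2 uM, which shows that the second chain can go without the number rising. Nothing measured in this set bears on why the number falls with this change.

Going by these compounds, whether a shorter chain such as ethyl, or a hydroxyl group or a carboxylic acid, on this same aromatic carbon would give a number close to that of compound 4 stays open, as does the outcome of replacing the remaining dec-1-en-1-yl group with hydrogen. On these data alone, it is also open whether the same change would give a step of similar size on compound 2, where the double bonds are drawn E.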